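The source may hold more compounds than are shown below. What is called first, only, known or untested is meant among the compounds shown, and "the series" means these compounds.

Working notes on the series. In a functional assay on HCT-116 cells (Homo sapiens) for antiproliferative activity, read by MTT assay, with a stated time of 72 h (a higher number here means a weaker inhibitor, a lower number a stronger inhibitor), compound 1 `O=C(CCc1cccc2c1B(O)OC2)Nc1ccccc1` gives 350 nM, compound 2 `CC(C)c1cccc(NC(=O)CCc2cccc3c2B(O)OC3)c1` gives 1600 nM and compound 3 `CSc1ccc(-c2cccc(NC(=O)CCc3cccc4c3B(O)OC4)c2)cc1` gives 180 nM. Compound 3 has the lowest number of the three, yet a 1.9-fold lower number from compound 1 to compound 3 (0.29 log units; within the scatter) stays within the scatter, while an 8.9-fold lower number from compound 2 to compound 3 (0.95 log units; beyond the scatter) goes beyond it. Next comes compound 4 `N#Cc1cccc(-c2cccc(NC(=O)CCc3cccc4c3B(O)OC4)c2)c1`, with 3-cyanophenyl in place of 4-(methylsulfanyl)phenyl on an aromatic carbon. Among the compounds with values here, no measured step exchanges one such ring group for another. The closest evidence is a 1.9-fold lower number from compound 1 to compound 3 (0.29 log units; within the scatter), whereas the isopropyl step, a 4.6-fold higher number from compound 1 to compound 2 (0.66 log units; beyond the scatter), is modest. The estimated step in this assay is a 1.4-fold higher number from compound 3 to compound 4 (0.14 log units; within the scatter), which is expected to stay within the scatter. Compound 4 is expected at 250 nM, within an estimated range of 90 nM to 700 nM.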

Compound 4, half-maximal inhibitory concentration: 140 nM
For compound 4 the middle estimate is 1.8-fold (0.25 log units) above the measured one; low and high end bracket the measured number.
By their numbers in this assay, from the lowest: compounds 4, 3 and 1 (each within the scatter of the next, the first and the last beyond it); then compound 2.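

The step of a 1.3-fold lower number from compound 3 to compound 4 (0.11 log units; within the scatter) shows that 3-cyanophenyl and 4-(methylsulfanyl)phenyl are not told apart at this position. Against hydrogen, 3-cyanophenyl gives a 2.5-fold lower number from compound 1 to compound 4 (0.40 log units; beyond the scatter) and so goes beyond the scatter where 4-(methylsulfanyl)phenyl did not, while against isopropyl it gives an 11-fold lower number from compound 2 to compound 4 (1.06 log units; beyond the scatter) as a large step. Nothing at hand explains these steps.

Open, on these data alone, is whether the nitrile's place on the ring matters, as 4-cyanophenyl would show. Also open, as far as these compounds go, is whether a phenyl ring carrying an amine or a carboxylic acid holds this level.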